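Shikonin ester side chains and cytotoxicity toward prostate cancer cells

The source may hold more compounds than are shown below. What is called first, only, known or untested is meant among the compounds shown, and "the series" means these compounds.

The compounds measured so far, in a functional assay on DU-145 cells (Homo sapiens) for cytotoxicity, read by MTT assay; on this read-out lower numbers stand for stronger inhibition and higher numbers for weaker inhibition:
compound 1 `CCCCC(CC(=O)O[C@H](CC=C(C)C)C1=CC(=O)c2c(O)ccc(O)c2C1=O)OC(C)=O` gives 67700 nM;
compound 2 `CC(C)=CC[C@@H](OC(=O)CC(O)c1ccccc1)C1=CC(=O)c2c(O)ccc(O)c2C1=O` gives 17000 nM;
compound 3 `CC(C)=CC[C@@H](OCCO)C1=CC(=O)c2c(O)ccc(O)c2C1=O` gives 9900 nM.

Among these three numbers compound 2 holds the second highest. Its nearest neighbour is compound 3, whose value lies within the scatter of that of compound 2, so no order between the two can be claimed. Among the compounds with values here, compound 1 stands further off, and the one step that joins the two directly is a 4.0-fold lower number from compound 1 to compound 2 (0.60 log units; beyond the scatter).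

Compound 4 `CCC(O)(CC)CC(=O)O[C@H](CC=C(C)C)C1=CC(=O)c2c(O)ccc(O)c2C1=O` has not yet been measured. Its relation to compound 2 is 1-ethyl-1-hydroxypropyl in place of hydroxy(phenyl)methyl on a saturated chain carbon bound to a carbonyl carbon. Within the data shown here, the only measured step at the same place is the one from compound 1 to compound 2, and it was modest in size. Among the measured compounds shown here, no measured step exchanges a ring for an open chain at this position, so the direction of the new step rests on analogy alone. A small rise in the number is expected, roughly a 1.5-fold higher number from compound 2 to compound 4 (0.17 log units; within the scatter), with a range wide enough to include no change. Compound 4 is therefore estimated at 25000 nM, between 10000 nM and 60000 nM.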

Compound 4, half-maximal inhibitory concentration: 67000 nM
Estimate against measurement, compound 4: 2.7-fold (0.43 log units) below; the measured number lies above the stated range.
By their numbers in this assay, from the lowest: compounds 3 and 2 (each within the scatter of the next); then compounds 4 and 1 (each within the scatter of the next).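

In this assay the open chain does not behave like the ring-bearing group: 1-ethyl-1-hydroxypropyl in place of hydroxy(phenyl)methyl gives a 3.9-fold higher number from compound 2 to compound 4 (0.60 log units; beyond the scatter), although both groups count one hydrogen-bond donor and one acceptor. The two open-chain groups, 1-acetoxypentyl and 1-ethyl-1-hydroxypropyl, cannot be told apart, with a 1.0-fold lower number from compound 1 to compound 4 (0.00 log units; within the scatter), so among these three esters only compound 2, with its six-membered aromatic ring, stands apart at this place. The change from 2-hydroxyethyl to (2-ethyl-2-hydroxybutyl)carbonyl on the oxygen gives a 6.8-fold higher number from compound 3 to compound 4 (0.83 log units; beyond the scatter).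

Nothing shown here explains why these numbers shift. As far as these compounds go, whether a second aromatic ring, an amine or a carboxylic acid on this chain would follow compound 2 or compound 4 stays open.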